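Cyclopropyl in place of 3-hydroxyphenyl: expecting compound 4

A few compounds are considered here, and "the series" means these few. Any claim that something is new, unique, unknown or untested is made for them only; others in the source may bear on it.

In a functional assay on A549 cells (Homo sapiens) for antiproliferative activity, read by MTT assay, with a stated time of 72 h (on this read-out higher numbers stand for weaker inhibition and lower numbers for stronger inhibition), compound 1 `O=C1O/C(=C\Cn2cc(-c3ccc(Br)cc3)nn2)C(OCc2ccccc2)=C1OCc1ccccc1` gives > 100000 nM, which is a limit of the assay and not a number. Compound 2 `O=C1O[C@H]([C@@H](O)Cn2cc(-c3cc(C(F)(F)F)cc(C(F)(F)F)c3)nn2)C(OCc2ccccc2)=C1OCc1ccccc1` gives 28900 nM, while compound 3 `O=C1O[C@H]([C@@H](O)Cn2cc(-c3cccc(O)c3)nn2)C(OCc2ccccc2)=C1OCc1ccccc1` gives 59900 nM, the higher of the two numbers and so the weaker inhibition, a gap just beyond the usual scatter. Compound 4 `O=C1O[C@H]([C@@H](O)Cn2cc(C3CC3)nn2)C(OCc2ccccc2)=C1OCc1ccccc1` differs from compound 3 in one place, with cyclopropyl in place of 3-hydroxyphenyl on an aromatic carbon. Within the data shown here, no measured step isolates this change, so no clear shift in this assay is expected. The estimated step of a 1.2-fold higher number from compound 3 to compound 4 (0.07 log units; within the scatter) stays within the scatter. For compound 4 the expected value is 70000 nM, with an estimated range of 30000 nM to 100000 nM.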

Compound 4, half-maximal inhibitory concentration: 43900 nM
Beside the measured number, compound 4's estimate is 1.6-fold (0.20 log units) above it; low and high end bracket the measured number.
By their numbers in this assay, from the lowest: compounds 2, 4 and 3 (each within the scatter of the next, the first and the last beyond it). At a limit, above all of these: compound 1.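

Cyclopropyl in place of 3-hydroxyphenyl gives a 1.4-fold lower number from compound 3 to compound 4 (0.13 log units; within the scatter) in this assay, the first step shown at this aromatic carbon of the five-membered aromatic ring with 3 nitrogen. Here a six-membered aromatic ring of carbon only, with its hydrogen-bond donor and acceptor, gives way to a smaller three-membered ring with no shift beyond the scatter. Nothing shown accounts for this step. The compounds shown leave open whether an amine, a carboxylic acid or a longer chain at this carbon would move the number beyond the scatter.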